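A Chlorophenyl Urea Exchange in an Antiproliferative Series

The compounds below may be only part of what the source reports. "The series", "measured", "known", "first", "only" and "open" are said of these compounds alone.

Of the compounds shown here, two have been measured so far. In a functional assay on A549 cells (Homo sapiens) for antiproliferative activity, read by MTT assay (a higher number here means a weaker inhibitor, a lower number a stronger inhibitor), compound 1 `O=C(Nc1cccc(Cl)c1)Nc1cccc(CNc2ncnc3ccccc23)c1` gives only a limit, > 50000 nM, and not a number. Among the compounds with values here, compound 2 `COc1cc2ncnc(NCc3cccc(NC(=O)Nc4ccc(C)cc4)c3)c2cc1OC` gives 12900 nM, which makes it the only compound of the pair with a true number. Its position can therefore be described only against that limit, and the two compounds differ in more than one place, so no single change can be read from them.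

The next compound keeps most of compound 2 unchanged. In compound 3 `COc1cc2ncnc(NCc3cccc(NC(=O)Nc4ccccc4Cl)c3)c2cc1OC`, 2-chlorophenyl stands in place of 4-methylphenyl on an amide-type nitrogen (2-chlorophenyl in place of 4-methylphenyl on an amide-type nitrogen). Within the data shown here, no measured step in this small set shows what such an exchange does, so the expectation rests on compound 2 alone, with its 12900 nM. No shift beyond the usual scatter of this assay is expected in either direction, although a reading that reaches only a limit remains possible. The estimated step of a 1.2-fold higher number from compound 2 to compound 3 (0.07 log units; within the scatter) is correspondingly small. For compound 3, the expected value is 15000 nM, with an estimated range of 6000 nM to 40000 nM.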

Compound 3, half-maximal inhibitory concentration: 15200 nM
Compound 3: the middle estimate sits 1.0-fold (0.01 log units) below what was measured; the range from low to high includes it.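

Within the data shown here, the first step that can be read in this set, in this assay, is a 1.2-fold higher number from compound 2 to compound 3 (0.07 log units; within the scatter), with 2-chlorophenyl in place of 4-methylphenyl on an amide-type nitrogen. At this position, then, the exchange of one aryl group for the other leaves compound 2 and compound 3 indistinguishable in this read-out, which the earlier pair could not show. The step alters both what the aromatic ring carries and where it carries it, however, and the result cannot separate these two parts of the exchange, nor can a single pair show whether they offset each other or neither matters.

Compound 1 gives only a limit and not a number, and it differs from the other compounds in more than one place, so no steps to it can be read: the limit of > 50000 nM in this assay, at which 1 of the 3 values shown sits.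

Still open, as far as these compounds go, is whether this position would respond to a group of a different kind on the ring, such as a carboxylic acid or a dimethylamino group, or to 4-chlorophenyl, which would separate the choice of substituent from its place.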